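Volume of distribution: bicyclic ether amide versus hydroxycyclohexyl amide

This account rests on a few compounds, and the source may have more. Where it says the series, first, only, none or still open, it means among the compounds named here.

Two compounds of the series have been run in an ADME assay on the whole organism (Rattus norvegicus, strain Wistar Han) for pharmacokinetics, read by LC-MS, with a stated time of 7 h; a higher number here means that more of the compound sits outside the plasma, a lower number that more of the compound stays in the plasma. Compound 1 `CNC(=O)c1cc(C(=O)N[C@H]2[C@@H]3COC[C@@H]32)c([C@@H](C)c2ccccc2)o1` gives 2.7 L/kg. Compound 2 `CNC(=O)c1cc(C(=O)N[C@H]2[C@@H]3C[C@@H](O)C[C@@H]32)n([C@@H](C)c2cccc(Cl)c2)n1` gives 2.6 L/kg. Within the data shown here, compound 1 holds the higher of the two numbers, but the gap to compound 2 is within the scatter, so the two read as one level, and no ordered step between them can be drawn.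

Compound 3 `CNC(=O)c1cc(C(=O)N[C@H]2CC[C@H](O)CC2)c([C@@H](C)c2ccccc2)o1` is not yet measured in this assay. Its difference from compound 1 is a group of 7 heavy atoms (6 carbon, 1 oxygen; one six-membered non-aromatic ring of carbon only) in place of a group of 6 heavy atoms (5 carbon, 1 oxygen; one three-membered non-aromatic ring of carbon only, one five-membered non-aromatic ring with 1 hetero atom), on an amide-type nitrogen. Among the measured compounds shown here, no measured pair isolates this kind of exchange, so the direction of the step has to be guessed from the level set by the two measured compounds alone. Compound 2, which also carries a hydroxyl on its ring amine, sits at 2.6 L/kg, close to compound 1, and nothing in the data suggests that a hydroxyl-bearing ring amine pulls the value far off.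

The step from compound 1 to compound 3 is expected to be small, a 1.2-fold lower number from compound 1 to compound 3 (0.09 log units; within the scatter), and perhaps slightly downward rather than upward. Compound 3 is accordingly estimated at 2.2 L/kg, with a range of 1.2 L/kg to 4 L/kg.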

Compound 3, volume of distribution at steady state: 2.1 L/kg
Beside the measured number, compound 3's estimate is 1.0-fold (0.02 log units) above it; low and high end bracket the measured number.
By their numbers in this assay, from the lowest: compounds 3, 2 and 1 (each within the scatter of the next).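

In this assay, among these compounds, the first reading at this position is available: on the amide-type nitrogen, 4-hydroxycyclohexyl in place of the group holding a three-membered ring of carbon only and a five-membered ring with 1 hetero atom gives a 1.3-fold lower number from compound 1 to compound 3 (0.11 log units; within the scatter) and so no change that can be told from repeat measurement. The exchange is not a minor one on paper, since it swaps two rings for one six-membered ring of carbon only, adds a hydrogen-bond donor and takes the defined stereocentres from 3 to 2, so at this position and on this core the read-out tolerates a change of that kind. No measurement shown bears on why the read-out holds level across this exchange.

This is a single pair on the core of compound 1, and the same exchange on the core of compound 2 has no reading among the compounds shown. From the compounds shown here alone, whether a group of a different type on this nitrogen, such as a ring carrying an amine or a carboxylic acid, would move the number beyond the scatter also remains open.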